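Dropping the amine methyl from a propargylamine pyrrole

A few compounds are considered here, and "the series" means these few. Any claim that something is new, unique, unknown or untested is made for them only; others in the source may bear on it.

In an assay on mitochondria for inhibition of Amine oxidase [flavin-containing] A (Bos taurus), read by fluorescence (on this read-out lower numbers stand for stronger inhibition and higher numbers for weaker inhibition), compound 1 `C#CCN(C)Cc1ccc[nH]1` gives 5.4 nM, the lowest of the three numbers recorded. Its nearest neighbour is compound 3 `CN(CCCc1ccccc1)Cc1ccc[nH]1` at 50 nM, and the furthest is compound 2 `CN(Cc1ccccc1)Cc1ccc[nH]1` at 3500 nM; both gaps lie beyond the usual scatter. Compound 4 `C#CCNCc1ccc[nH]1` differs from compound 1 by hydrogen in place of methyl on an amine nitrogen. Among the compounds with values here, no measured pair shows this change, so its size is uncertain; a modest weakening, a step beyond the scatter, is expected in this assay, as the estimated step of a 3.7-fold higher number from compound 1 to compound 4 (0.57 log units; beyond the scatter) shows. Compound 4 is accordingly estimated at 20 nM, with a range from 5 nM to 80 nM.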

Compound 4, inhibition constant: 300 nM
For compound 4 the middle estimate is 15-fold (1.18 log units) below the measured one; measured number above the stated range.
By their numbers in this assay, from the lowest: compound 1; then compound 3; then compound 4; then compound 2.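

In this assay, within the data shown here, the methyl on this amine nitrogen matters far more than the earlier compounds could show: putting hydrogen in its place gives a 56-fold higher number from compound 1 to compound 4 (1.74 log units; beyond the scatter) and removes only one carbon. Among these compounds, this is the only measured pair that isolates this change. Nothing available explains the size of the step.

Going by these compounds, whether an ethyl or a longer chain on this nitrogen would match compound 1 remains open. So does whether the same exchange would cost as much in compound 2 or compound 3.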